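The source may hold more compounds than are shown below. What is called first, only, known or untested is meant among the compounds shown, and "the series" means these compounds.

Compound 1 `COc1cc(C)cc(-c2c(-c3ccnc(-c4ccc(C(C)=O)cc4)c3)cnn2CC#N)c1`: 105% in a functional assay on Malme-3M cells (Homo sapiens) for cytotoxicity, read by sulforhodamine B assay, with a stated time of 48 h, tested at 0.001 uM; a lower number here means a stronger effect, a higher number a weaker effect of the compound at the concentration tested
Compound 2 `COc1cc(C)cc(-c2nn(CC#N)cc2-c2ccc(-c3cccc(C(C)=O)c3)nc2)c1`: 97% in this assay

Compound 1 stands with its number inside the scatter of compound 2, and neither compound shows a cytotoxic effect at the concentration tested in this assay. Compound 3 `COc1cc(C)cc(-c2c(-c3ccnc(-c4ccc(N(C)C)cc4)c3)cnn2CC#N)c1` has not been measured; it differs from compound 1 by dimethylamino in place of acetyl on an aromatic carbon. No change between two measured compounds is known, so nothing anchors a direction. Because compound 1 reads 105%, the step of a number 5 percentage points lower from compound 1 to compound 3 (within the scatter) is expected to stay within the scatter. Compound 3 is therefore estimated at 100%, with a range from 85% to 115%.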

Compound 3, a percentage reported as activity, at one concentration (the size of the read-out at that concentration, not a potency): 97%
For compound 3 the middle estimate is 3 percentage points above the measured one; the range from low to high includes it.
By their numbers in this assay, from the lowest: compounds 2, 3 and 1 (each within the scatter of the next).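

Replacing acetyl with dimethylamino on the aromatic carbon para to a large group gives a number 8 percentage points lower from compound 1 to compound 3 (within the scatter) in this assay. Among the compounds shown here, this is the first step that can be read at this position, and it shows that the two groups cannot be told apart here at the concentration tested, with neither showing a cytotoxic effect. No evidence bears on this result.

As far as these compounds go, whether a carboxylic acid or a longer alkyl chain at this position would give a different reading stays open. So does whether compound 1 and compound 3 would separate at higher concentrations.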